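A few compounds are considered here, and "the series" means these few. Any claim that something is new, unique, unknown or untested is made for them only; others in the source may bear on it.

Compound 2 (`CCC(C)(C)c1ccc2nc(N)sc2c1`) stands only at a limit: in a functional assay on the whole organism with Rattus norvegicus as the target (on this read-out higher numbers stand for an effect only at larger amounts of compound and lower numbers for an effect already at smaller amounts), compound 2 gives > 10 mg/kg as a limit of the assay, not a number. Compound 1 (`CC(C)(C)Oc1ccc2nc(N)sc2c1`) gives > 10 mg/kg in this assay and this too is a limit. For the measured compounds named here, the series so far therefore rests on the limit of > 10 mg/kg in this assay, at which 2 of the 2 values shown sit, and offers no measured potency to start from.

Compound 3 (`Nc1nc2ccc(CC(F)(F)F)cc2s1`) carries 2,2,2-trifluoroethyl in place of 1,1-dimethylpropyl on an aromatic carbon. Going by the values given here, the same position changed in the only measured step (a step that the two limits leave unreadable from compound 1 to compound 2) but the size of that step cannot be read, so it gives neither a size nor a direction to carry over.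

In this assay the expected step is estimated as a number no higher from compound 2 to compound 3 (the limit leaves the size open) and this estimate is loose, with no firm direction. In this assay the estimated value for compound 3 is 10 mg/kg with an expected range from 3 mg/kg to 30 mg/kg. There is also a real chance that compound 3 will again yield only a limit.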

Compound 3, dose for half-maximal effect: 8 mg/kg
Estimate against measurement, compound 3: 1.3-fold (0.10 log units) above, within the range that was stated.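

With 2,2,2-trifluoroethyl on this aromatic carbon the series gains its first number in this assay: compound 3 gives 8 mg/kg and so shows that this position can carry a group with a readable dose, which neither 1,1-dimethylpropyl nor tert-butoxy provided here. Exchanging 1,1-dimethylpropyl for 2,2,2-trifluoroethyl gives an at least 1.2-fold lower number from compound 2 to compound 3 (0.09 log units; that floor lies within the scatter) and exchanging tert-butoxy for it gives an at least 1.2-fold lower number from compound 1 to compound 3 (0.09 log units; that floor lies within the scatter) and these floors alone do not establish a real gain over either earlier group. From the compounds shown here alone, the true size of both steps stays unknown because they rest on limits rather than numbers: the limit of > 10 mg/kg in this assay, at which 2 of the 3 values shown sit.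

The compounds shown do not separate a contribution of the fluorine atoms from that of the shorter chain, and a plain ethyl group at the same place would be the direct comparison for compound 3. Nor do they show whether other groups on this carbon, such as trifluoromethyl, an amine or a longer fluorinated chain, would give a lower dose than compound 3 or fall back to a limit.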